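The compounds below may be only part of what the source reports. "The series", "measured", "known", "first", "only" and "open" are said of these compounds alone.

Measured in a functional assay on MCF7 cells (Homo sapiens) for inhibition, read by sulforhodamine B assay; on this read-out higher numbers stand for weaker inhibition and lower numbers for stronger inhibition:
- compound 1 `O=C1C(Nc2ccccc2)=CC(=O)c2c1nc1n2[C@H]2OC[C@@H](O)[C@H]2OC1`: > 4000 nM, a limit
- compound 2 `CCc1ccc(NC2=CC(=O)c3c(nc4n3[C@H]3OC[C@@H](O)[C@H]3OC4)C2=O)cc1`: 8990 nM
- compound 3 `O=C1C(N2CCCCC2)=CC(=O)c2c1nc1n2[C@H]2OC[C@@H](O)[C@H]2OC1`: > 8000 nM, a limit

Compound 3 stands only as a limit, > 8000 nM. Compound 4 `O=C1C(NC2CC2)=CC(=O)c2c1nc1n2[C@H]2OC[C@@H](O)[C@H]2OC1` differs from it as follows: cyclopropylamino in place of piperidin-1-yl on a double-bonded ring carbon. This puts cyclopropylamino in place of piperidin-1-yl on a double-bonded ring carbon. The measured changes at this place are a step that the two limits leave unreadable from compound 1 to compound 3 and a step that the limit leaves unreadable from compound 2 to compound 3, so neither gives a size to carry over. Going by the values given here, compound 2, at 8990 nM, is the only exact number in the set and anchors the expectation. No clear move in either direction is expected in this assay, and the estimated change is a step that the limit leaves unreadable from compound 3 to compound 4. The expected value for compound 4 is 10000 nM, within 4000 nM to 30000 nM.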

Compound 4, half-maximal inhibitory concentration: > 16000 nM
Compound 4 was reported as a limit; the forecaster's own chance of this, stated with the estimate: 55%; middle value at least 1.6-fold (0.20 log units) from the limit.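

In this assay, going by these compounds alone, cyclopropyl in place of 4-ethylphenyl on the amine nitrogen gives an at least 1.7-fold higher number from compound 2 to compound 4 (0.25 log units; that floor lies within the scatter) as the first readable step at this position. Compound 4 is only a limit, > 16000 nM as reported, so this step shows no gain in inhibition and no loss beyond the scatter. The other new steps cannot be read.

Within the data shown here, with compound 2 as the only exact value, the size of any change at this double-bonded ring carbon remains undetermined. Going by these compounds, whether morpholin-4-yl or a longer chain such as n-butylamino would give an exact value also stays open.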